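A few compounds are considered here, and "the series" means these few. Any claim that something is new, unique, unknown or untested is made for them only; others in the source may bear on it.

Measured compounds:
- compound 1, `CC(C)(C)c1cc(C(=O)NC2CCN(Cc3ccccc3)CC2)cc(C(C)(C)C)c1O`: 85100 nM
- compound 2, `CC(C)(C)c1cc(CCC(=O)NC2CCN(Cc3ccccc3)CC2)cc(C(C)(C)C)c1O`: 70400 nM
- compound 3, `COc1ccc(CN2CCC(CCNC(=O)/C=C/c3cc(C(C)(C)C)c(O)c(C(C)(C)C)c3)CC2)cc1`: 6700 nM

In an assay on isolated protein for inhibition of Amine oxidase [flavin-containing] B (Homo sapiens), read by fluorescence, with stated times of 15 min and 20 min (on this read-out lower numbers stand for stronger inhibition and higher numbers for weaker inhibition), compound 3 gives the lowest number of the three; compound 2 and compound 1 both stand beyond the scatter above it. Compound 4, `CC(C)(C)c1cc(/C=C/C(=O)NCCC2CCN(Cc3ccc(F)cc3F)CC2)cc(C(C)(C)C)c1O`, has not been measured. It differs from compound 3 in one place: 2,4-difluorophenyl in place of 4-methoxyphenyl on a saturated chain carbon bound to an amine nitrogen in a ring. For the measured compounds named here, no pair of measured compounds shows this change, so its size is not known from the series. With the shared core, the propenamide and the two-carbon chain to the ring kept, no step beyond the scatter is expected; the estimated step of a 1.2-fold higher number from compound 3 to compound 4 (0.08 log units; within the scatter) is small in either direction. Compound 4 is therefore estimated at 8000 nM, with a range from 2500 nM to 25000 nM.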

Compound 4, half-maximal inhibitory concentration: 12500 nM
Compound 4: middle estimate off by 1.6-fold (0.19 log units), on the low side; the range from low to high includes it.
By their numbers in this assay, from the lowest: compounds 3 and 4 (each within the scatter of the next); then compounds 2 and 1 (each within the scatter of the next).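

In this assay, for the compounds shown here, 2,4-difluorophenyl in place of 4-methoxyphenyl gives a 1.9-fold higher number from compound 3 to compound 4 (0.27 log units; within the scatter), the only measured step at this position on a saturated chain carbon bound to an amine nitrogen in a ring. For this pair, losing the hydrogen-bond acceptor counted in 4-methoxyphenyl, at an equal heavy-atom count, leaves the read-out within the scatter. No available evidence bears on the basis of this result.

Still open, from the compounds shown here alone, is whether 4-fluorophenyl alone would stay within the scatter of compound 3. Going by these compounds, a pyridyl or cyclohexyl group at this place also remains open.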